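Chloro in place of methoxy: a limit expected again

The source may hold more compounds than are shown below. What is called first, only, known or untested is meant among the compounds shown, and "the series" means these compounds.

Compound 1 `Cc1ccc(-c2n[nH]cc2N2CCCNCC2)cc1`: > 10000 nM
Compound 2 `COc1cccc(-c2n[nH]cc2N2CCNCC2)c1`: > 10000 nM
Compound 3 `COc1ccc(-c2n[nH]cc2N2CCNCC2)cc1`: > 10000 nM

In an assay on isolated protein for binding affinity to 5-hydroxytryptamine receptor 1E (Homo sapiens) (a lower number here means a stronger inhibitor, a higher number a weaker inhibitor), compound 2 gives > 10000 nM, which is a limit of the assay and not a number. The same holds for compound 1 with > 10000 nM and compound 3 with > 10000 nM, so nothing measured here rises above (the limit of > 10000 nM in this assay, at which 3 of the 3 values shown sit). Compound 4 `Clc1cccc(-c2n[nH]cc2N2CCNCC2)c1` is not yet measured; it differs from compound 2 by chloro in place of methoxy on an aromatic carbon. Among the measured compounds shown here, with no step between measured compounds available, the expectation is that this change moves the value by nothing beyond the usual scatter, and that compound 4 will again sit at the limit. Compound 4 is estimated at 20000 nM, within 5000 nM to 100000 nM. The expected step is a step that the limit leaves unreadable from compound 2 to compound 4.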

Compound 4, inhibition constant: > 10000 nM
Compound 4 ended at the assay's limit (the forecaster's own chance of this, stated with the estimate: 85%); the middle value does not contradict the limit.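

Compound 2 and compound 4 both sit at a limit of the assay and not at a number, so no step can be read between them: the limit of > 10000 nM in this assay, at which 4 of the 4 values shown sit.

The compounds shown leave open how strongly any of them binds in this assay, and how chloro and methoxy compare there.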